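Methylamino to isopropylamino step in the series

The source may hold more compounds than are shown below. What is called first, only, known or untested is meant among the compounds shown, and "the series" means these compounds.

Values so far in a physicochemical assay for acid dissociation, read by spectrophotometry
compound 1 `CCOc1cc(CN2CCC(NC(=O)c3ccc(NC)nc3)CC2)cc(OCC)c1F` gives 7.83
compound 2 `CCOc1cc(CN2CCC(NC(=O)c3ccc(Cl)nc3)CC2)cc(OCC)c1-c1ccc(F)cc1` gives 7.8
compound 3 `CCOc1cc(CN2CCC(NC(=O)c3ccc(NC)nc3)CC2)cc(OCC)c1-c1ccc(F)cc1` gives 7.86

Compound 1 stands at 7.83 in the middle of the three numbers, but the gaps on either side lie within the scatter, so no order is read from them. The next compound, compound 4 (`CCOc1cc(CN2CCC(NC(=O)c3ccc(NC(C)C)nc3)CC2)cc(OCC)c1F`), differs from compound 1 as follows: isopropyl in place of methyl on a nitrogen on an aromatic ring. Going by the values given here, no measured step changes the group on that nitrogen, so the evidence is indirect. Methylamino in place of chloro on an aromatic carbon gives a number 0.06 log units higher from compound 2 to compound 3 (within the scatter) and 4-fluorophenyl in place of fluoro on an aromatic carbon gives a number 0.03 log units higher from compound 1 to compound 3 (within the scatter) in the same read-out. Neither step goes beyond the scatter, and that includes the one that introduces the methylamino group. The expected result is a number 0.02 log units higher from compound 1 to compound 4 (within the scatter) and therefore no step beyond the scatter. Compound 4 is estimated at 7.85 (expected range 7.6 to 8.1).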

Compound 4, acid dissociation constant: 7.84
For compound 4 the middle estimate is 0.01 log units above the measured one; the range from low to high includes it.
By their numbers in this assay, from the lowest: compounds 2, 1, 4 and 3 (each within the scatter of the next).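

Going by these compounds alone, none of the steps among compounds 1 to 3 changes the group on the nitrogen of the methylamino substituent, and this step is the first direct reading at that place. In this assay, isopropyl in place of methyl on a nitrogen on an aromatic ring gives a number 0.01 log units higher from compound 1 to compound 4 (within the scatter), so this change of size on that nitrogen, from one heavy atom to three, leaves the read-out within the scatter in the fluoro compounds. Nothing measured on these compounds accounts for this result.

The compounds shown leave open whether a group of another kind on that nitrogen, such as a longer chain, a chain ending in a carboxylic acid or one carrying a second amine, would move the read-out beyond the scatter. They also leave open whether isopropylamino behaves the same way with 4-fluorophenyl in place of fluoro.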